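Ether chain extension, compound 2 to compound 3

The compounds below may be only part of what the source reports. "The series", "measured", "known", "first", "only" and "open" are said of these compounds alone.

Compound 1 `COCc1cc(=O)c(O)co1` with -0.62
Compound 2 `CCCOCc1cc(=O)c(O)co1` with 0.3

In an ADME assay for lipophilicity (a higher number here means a more lipophilic compound, a lower number a more polar compound), compound 2 is the higher of the two measured compounds, beyond the scatter from compound 1. Compound 3 `CCCCOCc1cc(=O)c(O)co1` follows from compound 2 through methyl in place of hydrogen on a saturated chain carbon, three bonds along the chain from an oxygen on a saturated carbon (propyl to butyl). Only a number 0.92 log units higher from compound 1 to compound 2 (beyond the scatter) bears on this change. That step put ethyl in place of hydrogen and this one puts methyl in place of hydrogen, so a smaller move in the same direction is expected. In this assay an upward a number 0.45 log units higher from compound 2 to compound 3 (beyond the scatter) is expected. Compound 3 is estimated at 0.75 (range 0.5 to 1.05).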

Compound 3, distribution coefficient: 0.78
The estimate for compound 3 lay 0.03 log units below the measured number, and the stated range covers the measured number.
By their numbers in this assay, from the lowest: compound 1; then compound 2; then compound 3.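

In this assay the ether chain keeps responding beyond propyl: butyl in place of propyl still gives a rise beyond the scatter (a number 0.48 log units higher from compound 2 to compound 3 (beyond the scatter)). Counted from the methyl end of the series, propyl in place of hydrogen gives the largest step shown (a number 1.40 log units higher from compound 1 to compound 3 (beyond the scatter)), and among compounds 1, 2 and 3 none goes against the order of chain length. Nothing available explains this rise.

Going by these compounds, whether the trend extends to a longer chain such as hexyl remains open. So does the effect of an amine or a carboxylic acid at the chain end.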